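This account rests on a few compounds, and the source may have more. Where it says the series, first, only, none or still open, it means among the compounds named here.

Values in a functional assay on RPMI-8226 cells (Homo sapiens) for antiproliferative activity, read by MTT assay, with a stated time of 72 h; a higher number here means a weaker inhibitor, a lower number a stronger inhibitor:
Compound 1 `COc1ccc(-c2ccc3ncnc(N[C@H]4CCN(C(=O)C5CC5)C4)c3c2)cn1`: 1460 nM
Compound 2 `COc1ncc(-c2ccc3ncnc(N[C@H]4CCN(C(=O)C5CCOCC5)C4)c3c2)cc1C#N`: 4340 nM

Compound 2 has the higher number of the pair, and its gap to compound 1 lies beyond the scatter. The two compounds differ in more than one place, so their gap isolates no single change. Compound 3 `COc1ncc(-c2ccc3ncnc(N[C@H]4CCN(C(=O)C5CCOCC5)C4)c3c2)cc1[N+](=O)[O-]` carries nitro in place of cyano on an aromatic carbon, ortho to a methoxy group: nitro in place of cyano on an aromatic carbon. Among the measured compounds shown here, no measured pair covers this change, so the expectation starts from compound 2 at 4340 nM, with no step beyond the scatter expected in this assay in either direction. The expected change is a 1.2-fold lower number from compound 2 to compound 3 (0.09 log units; within the scatter). The estimate for compound 3 is 3500 nM, with an expected range of 1200 nM to 10000 nM.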

Compound 3, half-maximal inhibitory concentration: 2710 nM
The estimate for compound 3 lay 1.3-fold (0.11 log units) above the measured number; the measured number falls inside the stated range.
By their numbers in this assay, from the lowest: compounds 1, 3 and 2 (each within the scatter of the next, the first and the last beyond it).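

Swapping 5-cyano-6-methoxypyridin-3-yl for 6-methoxy-5-nitropyridin-3-yl gives the series its first single-place comparison: this assay shows a 1.6-fold lower number from compound 2 to compound 3 (0.20 log units; within the scatter). On this aromatic carbon, ortho to a methoxy group, the assay therefore does not separate cyano from nitro. No measurement at hand bears on the reason for this result.

On these data alone, whether an amine or a carboxylic acid on this carbon would give a step beyond the scatter remains open. The gap between compound 1 and compound 2 also cannot yet be divided between the places where they differ.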